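Replacing Bromo with Nitro in a Cytotoxic Series

The source may report more compounds than this note shows. Statements on the series, on what has been measured and on what is new or still open speak of the compounds shown alone.

Of the compounds shown here, three sharing one core have been measured so far in a functional assay on MCF7 cells (Homo sapiens) for cytotoxicity, read by MTT assay, with a stated time of 96 h (a higher number here means a weaker inhibitor, a lower number a stronger inhibitor), and they differ in one group. Compound 1 `COc1cccc(-n2cc(C(=O)c3cc(OC)c(OC)c(OC)c3)c(-c3ccccc3)c2)c1` carries 3-methoxyphenyl on an aromatic nitrogen and gives 500 nM as its number. Compound 2 `COc1cc(C(=O)c2cn(-c3ccc(Cl)cc3)cc2-c2ccccc2)cc(OC)c1OC` carries 4-chlorophenyl there and gives 140 nM as its number. Compound 3 `COc1cc(C(=O)c2cn(-c3ccc(Br)cc3)cc2-c2ccccc2)cc(OC)c1OC` carries 4-bromophenyl and gives 20 nM as the lowest number of the three, which makes it the strongest inhibitor so far.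

Compound 4 `COc1cc(C(=O)c2cn(-c3ccc([N+](=O)[O-])cc3)cc2-c2ccccc2)cc(OC)c1OC` is still unmeasured. It has nitro in place of bromo on an aromatic carbon, para to a large group. The closest measured change is a 7.0-fold lower number from compound 2 to compound 3 (0.85 log units; beyond the scatter) and it is modest but beyond the scatter. Wider changes also count: a 25-fold lower number from compound 1 to compound 3 (1.40 log units; beyond the scatter) is large while a 3.6-fold lower number from compound 1 to compound 2 (0.55 log units; beyond the scatter) is modest. Among the measured compounds shown here, no nitro compound has been measured, so there is no direct guide. For the measured compounds named here, with compound 3 at 20 nM as the lowest number so far, a modest step to a higher number is expected in this assay for this swap. The estimated change is a 5.0-fold higher number from compound 3 to compound 4 (0.70 log units; beyond the scatter) on this reasoning. Compound 4 is estimated at 100 nM with a range of 25 nM to 400 nM around that figure.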

Compound 4, half-maximal inhibitory concentration: 4000 nM
The estimate for compound 4 lay 40-fold (1.60 log units) below the measured number; the whole stated range lies below it.
By their numbers in this assay, from the lowest: compound 3; then compound 2; then compound 1; then compound 4.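

In this assay, among the compounds shown here, replacing bromo with nitro at this place, para to a large group, gives a 200-fold higher number from compound 3 to compound 4 (2.30 log units; beyond the scatter), a larger step than any among the earlier compounds, so this position can do far more than shift the number modestly. The loss is also large against the chloro compound, at a 29-fold higher number from compound 2 to compound 4 (1.46 log units; beyond the scatter), and nitro even falls behind the 3-methoxyphenyl compound, the weakest of the first three, at an 8.0-fold higher number from compound 1 to compound 4 (0.90 log units; beyond the scatter), which makes compound 4 the weakest of the four. Nothing available here shows what about the nitro group lies behind this loss.

The compounds shown leave open whether the loss is particular to nitro or would also appear with other groups at this place, such as a nitrile, an amine or a carboxylic acid. For the compounds shown here, they also leave open whether the gain seen on going from chloro to bromo continues to iodo, and whether a methoxy group placed where these halogens sit would behave differently from the one in compound 1.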